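FAAH inhibitor series: aryl-oxazole ketones, heteroaryl replacement

This account rests on a few compounds, and the source may have more. Where it says the series, first, only, none or still open, it means among the compounds named here.

Measured compounds:
- compound 1, `COc1ccccc1-c1cnc(C(=O)CCCCCCc2ccccc2)o1`: 400 nM
- compound 2, `Nc1cccc(-c2cnc(C(=O)CCCCCCc3ccccc3)o2)c1`: 19 nM
- compound 3, `Cc1ccnc(-c2cnc(C(=O)CCCCCCc3ccccc3)o2)c1`: 0.6 nM

All three share a core that carries a ketone chain ending in a phenyl and an aromatic group on the five-membered ring. In an assay (Rattus norvegicus) for inhibition of Fatty-acid amide hydrolase 1 (Homo sapiens) (a lower number here means a stronger inhibitor, a higher number a weaker inhibitor), compound 2 stands second highest of the three numbers; the nearest is compound 1 with a 21-fold lower number from compound 1 to compound 2 (1.32 log units; beyond the scatter), and the furthest is compound 3 with a 32-fold lower number from compound 2 to compound 3 (1.50 log units; beyond the scatter). The third pairing is a 670-fold lower number from compound 1 to compound 3 (2.82 log units; beyond the scatter).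

Compound 4, `O=C(CCCCCCc1ccccc1)c1ncc(-c2ccncn2)o1`, is not yet measured. Its change from compound 2 is pyrimidin-4-yl in place of 3-aminophenyl on an aromatic carbon. The step from compound 2 to compound 3 bears most directly on it: there a six-membered carbon-only ring gave way to a ring with a nitrogen, and the number fell far beyond the scatter. Compound 4 also brings in a nitrogen-containing six-membered ring, though it differs from compound 3 in the number of nitrogens and in lacking the methyl, so the step is expected to be in the same direction but smaller: the estimated step is a 4.8-fold lower number from compound 2 to compound 4 (0.68 log units; beyond the scatter). Compound 4 is therefore estimated at 4 nM in this assay, with a range from 0.8 nM to 20 nM.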

Compound 4, inhibition constant: 2.3 nM
Compound 4: the middle estimate sits 1.7-fold (0.24 log units) above what was measured, and the stated range covers the measured number.
By their numbers in this assay, from the lowest: compound 3; then compound 4; then compound 2; then compound 1.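

At the aromatic carbon next to the ring oxygen, the pyrimidin-4-yl ring in this assay gives an 8.3-fold lower number from compound 2 to compound 4 (0.92 log units; beyond the scatter) and a 170-fold lower number from compound 1 to compound 4 (2.24 log units; beyond the scatter), so a nitrogen-bearing ring without a methyl also outperforms both carbon-only aryl groups shown. With a 3.8-fold higher number from compound 3 to compound 4 (0.58 log units; beyond the scatter), the pyrimidin-4-yl ring does not match the 4-methylpyridin-2-yl ring, so a higher count of ring hetero atoms brings no gain over that group in this set, though the two rings also differ in the methyl. No supporting data bear on the reason for these differences.

Going by these compounds, the separate contributions of the methyl, the second ring nitrogen and the nitrogen placement remain open. A plain pyridin-2-yl or a methyl-substituted pyrimidin-4-yl would separate them, and an unsubstituted phenyl would give a carbon-only reference without the amine or methoxy group.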